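Removing a methyl from a chalcone: methoxy to hydroxy

This account rests on a few compounds, and the source may have more. Where it says the series, first, only, none or still open, it means among the compounds named here.

Measured so far:
compound 1, `COc1cc(O)c(C(=O)/C=C/c2ccccc2SC)c(OC)c1`, 16600 nM
compound 2, `COc1cc(OC)c(C(=O)/C=C/c2ccccc2)c(OC)c1`, 15500 nM
compound 3, `COc1cc(OC)c(C(=O)/C=C/c2ccccc2OC)c(OC)c1`, 9800 nM

In a functional assay on Huh-7 cells (Homo sapiens) for cytotoxicity, with a stated time of 48 h (a lower number here means a stronger inhibitor, a higher number a weaker inhibitor), compound 3 gives the lowest number of the three, yet its gap to compound 2 and to compound 1 stays within the usual scatter, so no ranking among them can be read. Compound 4, `COc1cc(O)c(C(=O)/C=C/c2ccccc2OC)c(OC)c1`, differs from compound 3 by hydrogen in place of methyl on an oxygen on an aromatic ring. Going by the values given here, the only measured step, a 1.6-fold lower number from compound 2 to compound 3 (0.20 log units; within the scatter), concerns a different change and does not bear on this one. Compound 1 carries the same hydroxy group as compound 4 but also differs elsewhere, and its value sits close to compound 2 and compound 3. Compound 4 is therefore expected to show no step beyond the scatter, a 1.1-fold higher number from compound 3 to compound 4 (0.05 log units; within the scatter), with an estimate of 11000 nM between 4500 nM and 27000 nM.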

Compound 4, half-maximal inhibitory concentration: > 20000 nM
Compound 4: no number, only a limit; the forecaster's own chance of this, stated with the estimate: 5%; middle value at least 1.8-fold (0.25 log units) from the limit.
By their numbers in this assay, from the lowest: compounds 3, 2 and 1 (each within the scatter of the next). At a limit, above all of these: compound 4.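

Turning the methoxy into a hydroxy gives an at least 2.0-fold higher number from compound 3 to compound 4 (0.30 log units; that floor lies within the scatter) in this assay, so this change does not bring the number down, though a real loss of strength is not established. With the hydroxy kept, methoxy in place of methylsulfanyl on an aromatic carbon gives an at least 1.2-fold higher number from compound 1 to compound 4 (0.08 log units; that floor lies within the scatter). Compound 4 has only a limit, so neither step has a known true size: the limit of > 20000 nM in this assay, at which 1 of the 4 values shown sits.

On these data alone, what an amine, a carboxylic acid or a longer ether chain would do in place of this methoxy stays open.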